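Swapping the phenol for a methyl thioether

The compounds below may be only part of what the source reports. "The series", "measured", "known", "first", "only" and "open" are said of these compounds alone.

Measured compounds:
- compound 1 `Cn1c(=O)c(=O)n(C2CCCC2)c2nc(N/N=C/c3ccc(O)cc3)ncc21`: > 100000 nM
- compound 2 `Cn1c(=O)c(=O)n(C2CCCC2)c2nc(N/N=C/c3ccc(F)cc3Cl)ncc21`: 11000 nM
- compound 3 `COc1ccc(/C=N/Nc2ncc3c(n2)n(C2CCCC2)c(=O)c(=O)n3C)cc1`: > 100000 nM

All three share one core and differ only in the aryl group on the carbon with a double bond to nitrogen. In a functional assay on A549 cells (Homo sapiens) for antiproliferative activity, read by MTT assay (on this read-out lower numbers stand for stronger inhibition and higher numbers for weaker inhibition), compound 1 gives > 100000 nM, which is a limit of the assay and not a number. Compound 3 gives > 100000 nM, also a limit. Within the data shown here, compound 2 gives 11000 nM, the only true number here, and the step of an at least 9.0-fold lower number from compound 1 to compound 2 (0.95 log units; beyond the scatter) is therefore the one change that moves the read-out beyond the scatter; the step that the two limits leave unreadable from compound 1 to compound 3 cannot be sized, as the limit of > 100000 nM in this assay, at which 2 of the 3 values shown sit, shows.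

The new compound 4 `CSc1ccc(/C=N/Nc2ncc3c(n2)n(C2CCCC2)c(=O)c(=O)n3C)cc1` differs from compound 1 by methylsulfanyl in place of hydroxy on an aromatic carbon. This change resembles the move to compound 3 more than the move to compound 2, since it again replaces the hydroxy with a small uncharged group rather than with the 2-chloro-4-fluorophenyl pattern. The closest step is therefore the unreadable one to compound 3, and no step beyond the scatter is expected. Compound 4 is expected to give about 100000 nM, with a range of 30000 nM to 300000 nM. The expected step is a number no higher from compound 1 to compound 4 (the limit leaves the size open), most likely another limit.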

Compound 4, half-maximal inhibitory concentration: 14100 nM
Beside the measured number, compound 4's estimate is 7.1-fold (0.85 log units) above it; the whole stated range lies above it.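

Among these compounds, the earlier compounds left the 2-chloro-4-fluorophenyl pattern as the only one with a true number in this assay, but a single methylsulfanyl group on an aromatic carbon, para to a large group, now gives one too, with an at least 7.0-fold lower number from compound 1 to compound 4 (0.85 log units; beyond the scatter). Removing the hydroxy is not enough by itself, since methoxy also has no hydroxy, yet the move from methoxy to methylsulfanyl gives an at least 7.0-fold lower number from compound 3 to compound 4 (0.85 log units; beyond the scatter), and the comparison with the halogen pattern gives a 1.3-fold higher number from compound 2 to compound 4 (0.11 log units; within the scatter), so a single sulfur-bearing group here matches the two-halogen pattern within the scatter. The two lower steps are only minimum sizes, as each starts from a value that is a limit of the assay and not a number: the limit of > 100000 nM in this assay, at which 2 of the 4 values shown sit.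

The compounds shown leave open whether the sulfur atom itself is needed, or whether a single chloro group, an amine or a longer chain such as ethylsulfanyl on the same carbon would serve equally well. They also leave open whether the methylsulfanyl group and a chloro group on one ring would together give a lower number than either pattern alone.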